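Dichlorophenyl in place of bromophenyl on a dihydropyridine core

The source may hold more compounds than are shown below. What is called first, only, known or untested is meant among the compounds shown, and "the series" means these compounds.

Measured so far in a functional assay (muscle tissue) with Cavia porcellus as the target; on this read-out lower numbers stand for an effect already at smaller amounts and higher numbers for an effect only at larger amounts of compound:
compound 1 `COC(=O)C1=C(C)N=C(C)/C(=C(\O)OC)C1c1cccc(Br)c1` gives 1.29 nM;
compound 2 `COC(=O)C1=C(C)N=C(C)/C(=C(\O)OC)C1c1cccc(C(F)(F)F)c1` gives 74.1 nM;
compound 3 `COC(=O)C1=C(C)N=C(C)/C(=C(\O)OC)C1c1cccc(OC(=O)c2ccccc2)c1` gives 6310 nM.

Compound 1 stands lowest of the three, with the step of a 57-fold higher number from compound 1 to compound 2 (1.76 log units; beyond the scatter) and the step of a 4900-fold higher number from compound 1 to compound 3 (3.69 log units; beyond the scatter) both leading upward from it. Compound 4 `COC(=O)C1=C(C)N=C(C)/C(=C(\O)OC)C1c1ccc(Cl)cc1Cl` differs from compound 1 thus: 2,4-dichlorophenyl in place of 3-bromophenyl on a saturated ring carbon. The measured steps all exchange one group on the aromatic ring of compound 1 and rise; none exchanges the whole ring, so they bear only loosely on this change. Compound 4 is therefore expected to stay near compound 1, with a step of a 2.3-fold higher number from compound 1 to compound 4 (0.37 log units; beyond the scatter) in this assay that may lie within the scatter or be modestly upward. The estimate for compound 4 is 3 nM, ranging from 0.5 nM to 30 nM.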

Compound 4, half-maximal effective concentration: 640 nM
The estimate for compound 4 lay 210-fold (2.33 log units) below the measured number, outside the stated range (above it).
By their numbers in this assay, from the lowest: compound 1; then compound 2; then compound 4; then compound 3.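

In this assay, the aromatic group on the saturated ring carbon proves far from interchangeable: 2,4-dichlorophenyl in place of 3-bromophenyl gives a 500-fold higher number from compound 1 to compound 4 (2.70 log units; beyond the scatter) and so removes most of what set compound 1 apart. Among these compounds, the earlier steps exchanged only one group at a single place on the aromatic ring, whereas this one changes both the halogen and the substitution pattern. Nothing available accounts for the rise. The compounds shown leave open whether it follows from the loss of bromo, the number of chlorines or where they sit, and how an amine or a carboxylic acid on the aromatic ring would read.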